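This account rests on a few compounds, and the source may have more. Where it says the series, first, only, none or still open, it means among the compounds named here.

In an ADME assay on microsomes from liver (Homo sapiens) for metabolic stability (a higher number here means faster removal of the compound, a lower number slower removal), compound 2 `CCOC(=O)N1C[C@@H]2C[C@H]1CN2c1nc(-c2cnc(N)c(OC(F)F)n2)cc(N2CC3CC2C3)n1` gives 11.1 mL/min/kg and compound 1 `CCOC(=O)N1C[C@@H]2C[C@H]1CN2c1nc(SC)cc(-c2cnc(N)c(OC(F)F)n2)n1` gives 12.3 mL/min/kg so the two stand within the scatter of each other. The change to compound 3 `CCOC(=O)N1C[C@@H]2C[C@H]1CN2c1nc(-c2cnc(N)c(OC(F)F)n2)cc(C2CC2)n1` is a group of 3 heavy atoms (3 carbon; one three-membered non-aromatic ring of carbon only) in place of a group of 6 heavy atoms (5 carbon, 1 nitrogen; one four-membered non-aromatic ring of carbon only, one five-membered non-aromatic ring with 1 hetero atom), on an aromatic carbon and brings in cyclopropyl. Among the measured compounds shown here, the one measured step at this place is a 1.1-fold lower number from compound 1 to compound 2 (0.04 log units; within the scatter) and it stayed within the scatter, so no step beyond the scatter is expected in this assay here, though a single step is thin support. The estimated 1.1-fold higher number from compound 2 to compound 3 (0.03 log units; within the scatter) is expected to stay within the scatter. The expected value for compound 3 is 12 mL/min/kg within a range of 7 mL/min/kg to 20 mL/min/kg for now.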

Compound 3, clearance: 12.6 mL/min/kg
Compound 3: middle estimate off by 1.1-fold (0.02 log units), on the low side; measured number inside the range.
By their numbers in this assay, from the lowest: compounds 2, 1 and 3 (each within the scatter of the next).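

At this aromatic carbon, this assay gives no step beyond the scatter for cyclopropyl against the larger group, a 1.1-fold higher number from compound 2 to compound 3 (0.06 log units; within the scatter), or against methylsulfanyl, a 1.0-fold higher number from compound 1 to compound 3 (0.01 log units; within the scatter). Across compounds 1, 2 and 3, a carbon-only group therefore reads the same as a group carrying sulfur and one carrying nitrogen. Nothing available explains this insensitivity.

Going by these compounds, whether a carboxylic acid or a longer alkyl chain at this place would move the clearance beyond the scatter remains open, and so does the effect of changes elsewhere on the shared core.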